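The source may report more compounds than this note shows. Statements on the series, on what has been measured and on what is new or still open speak of the compounds shown alone.

Working notes on the series.

Three compounds of the shared core carry a measured number in an assay on CHO-K1 cells for binding affinity to 5-hydroxytryptamine receptor 1B (Homo sapiens); on this read-out higher numbers stand for weaker inhibition and lower numbers for stronger inhibition. Compound 2 `CN(C)[C@H]1C[C@H](c2c[nH]c3ccc(CC(N)=O)cc32)C1` gives 1350 nM and stands at the high end of the set. Compound 1 `CN(C)[C@H]1C[C@H](c2c[nH]c3ccc(C(=O)NCc4ccccc4)cc32)C1` gives 316 nM, a lower number than compound 2 by a margin beyond the scatter. Compound 3 `N[C@H]1C[C@H](c2c[nH]c3ccc(Oc4ccccc4)cc32)C1` gives 9.55 nM, the lowest number of the three and far below compound 2; compound 3 also differs from compound 2 at the amine, so its two values show only that the gap is large, not which change carries it.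

Compound 4 `Cc1noc(-c2ccc3[nH]cc([C@H]4C[C@H](N(C)C)C4)c3c2)n1` is not yet measured. It differs from compound 2 in one place: 3-methyl-1,2,4-oxadiazol-5-yl in place of carbamoylmethyl on an aromatic carbon. Within the data shown here, no pair with this kind of change has a measured step in this assay, so the expectation rests on the spread of the three numbers: the carbamoylmethyl of compound 2 sits at the weak end, and both other substituents at the same place give lower numbers. For compound 4 the expectation is a downward step, an 11-fold lower number from compound 2 to compound 4 (1.05 log units; beyond the scatter), of a size beyond the scatter. The estimate for compound 4 in this assay is 120 nM, with a range from 30 nM to 500 nM.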

Compound 4, half-maximal inhibitory concentration: 832 nM
Compound 4: the middle estimate sits 6.9-fold (0.84 log units) below what was measured, and the stated range ends below it.
By their numbers in this assay, from the lowest: compound 3; then compound 1; then compounds 4 and 2 (each within the scatter of the next).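

In this assay, the replacement of carbamoylmethyl by 3-methyl-1,2,4-oxadiazol-5-yl gives a 1.6-fold lower number from compound 2 to compound 4 (0.21 log units; within the scatter), the first step measured between two compounds that differ in one place. At this aromatic carbon, two groups that differ in ring content and in hydrogen-bond count (the 1 donor of carbamoylmethyl against the 0 donors of the oxadiazole) therefore cannot be told apart in this assay, so the earlier view of carbamoylmethyl as a group apart at the weak end does not hold for this pair. No other measurement on hand bears on why the two groups read alike.

Still open, going by these compounds, is whether the low number of compound 3, 9.55 nM, belongs to its phenoxy group or to its unsubstituted amine, since a compound with phenoxy at this place and the dimethylamino group of compound 2 would be needed to separate the two. Also open, on these data alone, is how a carboxylic acid or a nitrile at this place would read against the flat step seen here, and whether the same swap behaves alike on the unsubstituted amine.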